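Swapping Chlorine for Fluorine on the Aryl Ring

The compounds below may be only part of what the source reports. "The series", "measured", "known", "first", "only" and "open" are said of these compounds alone.

Compound 2 `O=C(c1ccc(Br)o1)N1CCCCC1c1nnn(-c2cccc(Cl)c2)n1` gives 49 nM in an assay on cell membranes for displacement of a labelled ligand from metabotropic glutamate receptor 5 (Rattus norvegicus) (a lower number here means a stronger inhibitor, a higher number a weaker inhibitor), the lowest of the three numbers measured. Compound 1 `CC(C)C(=O)N1CCCCC1c1nnn(-c2cccc(Cl)c2)n1` gives 138 nM in this assay, and the step of a 2.8-fold lower number from compound 1 to compound 2 (0.45 log units; beyond the scatter) lies beyond the usual scatter. Compound 3 `Cc1ccc(C(=O)N2CCCC2c2nnn(-c3cccc(Cl)c3)n2)s1` gives 89.1 nM, which sits within the scatter of compound 2. Compound 4 `O=C(c1ccc(Br)o1)N1CCCCC1c1nnn(-c2cccc(F)c2)n1` differs from compound 2 only in fluoro in place of chloro on an aromatic carbon. For the measured compounds named here, the single measured step concerns the group on the carbonyl carbon, and compound 3 differs from compound 2 in more than one place, so no measured step bears on this halogen swap. Only a small change, likely within the scatter, is expected. Compound 4 is therefore expected to give about 95 nM, in the range 35 nM to 280 nM. That expectation corresponds to a step of a 1.9-fold higher number from compound 2 to compound 4 (0.29 log units; within the scatter).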

Compound 4, inhibition constant: 457 nM
Estimate against measurement, compound 4: 4.8-fold (0.68 log units) below, and the stated range ends below it.
By their numbers in this assay, from the lowest: compounds 2, 3 and 1 (each within the scatter of the next, the first and the last beyond it); then compound 4.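

In this assay, changing 3-chlorophenyl to 3-fluorophenyl gives a 9.3-fold higher number from compound 2 to compound 4 (0.97 log units; beyond the scatter) and shows that this aromatic position is sensitive: exchanging one halogen atom for another can matter here. The earlier compounds shown here varied only the acyl part and kept the chloro fixed, so they could not show this. Nothing available explains the loss.

Going by these compounds, it remains open whether the isopropyl amide of compound 1 would respond to the same swap in the same way. Also open, on these data alone, is how a methoxy or a nitrile would fare at this position.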